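Pyrimidinyl Capping of the Sulfonamide: Expected Potency Shift

The source may report more compounds than this note shows. Statements on the series, on what has been measured and on what is new or still open speak of the compounds shown alone.

Compound 1 `O=S(=O)(Nc1ccccn1)c1ccc(Nc2nncc3ccccc23)cc1` gives 86 nM in a functional assay on HL-60 cells (Homo sapiens) for antiproliferative activity, read by sulforhodamine B assay, with a stated time of 72 h; on this read-out lower numbers stand for stronger inhibition and higher numbers for weaker inhibition.
Compound 2 `NS(=O)(=O)c1ccc(Nc2nncc3ccccc23)cc1` gives 18 nM in this assay.

Within the data shown here, compound 2 holds the lowest of the two numbers in this assay; the single measured step, a 4.8-fold lower number from compound 1 to compound 2 (0.68 log units; beyond the scatter), separates it from compound 1. Compound 3 `O=S(=O)(Nc1ncccn1)c1ccc(Nc2nncc3ccccc23)cc1` is not yet measured and differs from compound 2 by pyrimidin-2-yl in place of hydrogen on a sulfonamide nitrogen. The step of a 4.8-fold lower number from compound 1 to compound 2 (0.68 log units; beyond the scatter) bears on this, as it removed an aromatic ring from the same sulfonamide nitrogen and lowered the number; restoring a ring is expected to raise it by a comparable amount. Compound 3 is therefore expected near 70 nM, between 25 nM and 200 nM. The expected step is a 3.9-fold higher number from compound 2 to compound 3 (0.59 log units; beyond the scatter).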

Compound 3, half-maximal inhibitory concentration: 67 nM
Compound 3: middle estimate off by 1.0-fold (0.02 log units), on the high side; the range from low to high includes it.
By their numbers in this assay, from the lowest: compound 2; then compounds 3 and 1 (each within the scatter of the next).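

In this assay, a 3.7-fold higher number from compound 2 to compound 3 (0.57 log units; beyond the scatter) shows that the rise in the number on placing an aromatic ring on the sulfonamide nitrogen is not confined to pyridin-2-yl. Exchanging pyridin-2-yl for pyrimidin-2-yl gives a 1.3-fold lower number from compound 1 to compound 3 (0.11 log units; within the scatter), so these two rings cannot be told apart at this position. No measurement at hand offers a reason for either step.

On these data alone, whether a methyl or an acetyl group on that nitrogen would fall nearer compound 2 or compound 3 stays open, as does the effect of a saturated ring such as piperidine.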